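Replacing a butyl chain with an oxolane ring

The source may hold more compounds than are shown below. What is called first, only, known or untested is meant among the compounds shown, and "the series" means these compounds.

Among the measured compounds shown here, compound 1, `CCCCn1nc(C(=O)N[C@H]2COc3ccccc3N(C)C2=S)nc1Cc1ccccc1`, gives 510 nM in a functional assay on HT-29 cells (Homo sapiens) for inhibition, read by luminescence and CellTiter-Glo, with a stated time of 24 h (a lower number here means that less compound is needed, a higher number that more compound is needed for the effect), the lowest of the three numbers measured so far. Compound 2, `CCCCCn1nc(C(=O)N[C@H]2COc3ccccc3N(C)C2=S)nc1Cc1ccccc1`, gives 805 nM, and compound 3, `CN1C(=S)[C@@H](NC(=O)c2nc(Cc3ccccc3)n(CCCCC#N)n2)COc2ccccc21`, gives 2680 nM. The step of a 1.6-fold higher number from compound 1 to compound 2 (0.20 log units; within the scatter) lies within the scatter, while the step of a 5.3-fold higher number from compound 1 to compound 3 (0.72 log units; beyond the scatter) and the step of a 3.3-fold higher number from compound 2 to compound 3 (0.52 log units; beyond the scatter) both lie beyond it.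

Compound 4, `CN1C(=S)[C@@H](NC(=O)c2nc(Cc3ccccc3)n(CC3CCOC3)n2)COc2ccccc21`, differs from compound 1 in one place: oxolan-3-yl in place of propyl on a saturated chain carbon bound to an aromatic nitrogen. The entering group brings a five-membered non-aromatic ring with one hetero atom and one hydrogen-bond acceptor, where compound 1 has only a saturated chain. The step of a 1.6-fold higher number from compound 1 to compound 2 (0.20 log units; within the scatter) shows that simply lengthening the chain changes little, whereas the step of a 5.3-fold higher number from compound 1 to compound 3 (0.72 log units; beyond the scatter) shows that adding a group with an acceptor at the chain end costs a modest amount. The ring change here adds an acceptor, though in a different shape from the nitrile of compound 3, so a modest rise in the number is expected, smaller than the step to compound 3.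

The estimate for compound 4 is therefore 1100 nM, within a range from 450 nM to 2800 nM, which is expected to correspond to the step of a 2.2-fold higher number from compound 1 to compound 4 (0.33 log units; beyond the scatter).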

Compound 4, half-maximal effective concentration: 4420 nM
Compound 4: middle estimate off by 4.0-fold (0.60 log units), on the low side, and the stated range ends below it.
By their numbers in this assay, from the lowest: compounds 1 and 2 (each within the scatter of the next); then compounds 3 and 4 (each within the scatter of the next).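

In this assay, compound 4 groups with the nitrile compound rather than with the plain saturated chains: it lies well away from both saturated compounds (an 8.7-fold higher number from compound 1 to compound 4 (0.94 log units; beyond the scatter); a 5.5-fold higher number from compound 2 to compound 4 (0.74 log units; beyond the scatter)), yet cannot be separated from the nitrile compound (a 1.6-fold higher number from compound 3 to compound 4 (0.22 log units; within the scatter)). Across these four compounds, both chains carrying a hydrogen-bond acceptor, the nitrile of compound 3 and the oxolan-3-yl ring of compound 4, give higher numbers than the saturated chains of compound 1 and compound 2, and no compound shown goes against this, although the two groups differ in shape and one contains a ring. Nothing measured here explains why these groups differ from the saturated chains.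

The compounds shown leave open whether the ring oxygen or the ring itself goes with the higher number, a question that a cyclopentyl group in the same place could help separate. They also leave open how other chain ends would behave, such as an amine or a carboxylic acid at the end of the butyl chain.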